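This account rests on a few compounds, and the source may have more. Where it says the series, first, only, none or still open, it means among the compounds named here.

- Compound 1 `COc1cc(C(=O)n2ccc3ccccc32)cc(OC)c1OC`: > 10000 nM (a limit of the assay, not a number)
- Compound 2 `CCn1ccc2cc(C(=O)c3cc(OC)c(OC)c(OC)c3)ccc21`: 36 nM
- Compound 3 `CCCn1ccc2cc(C(=O)c3cc(OC)c(OC)c(OC)c3)ccc21`: 1900 nM

In a functional assay on KB cells (Homo sapiens) for inhibition, with a stated time of 72 h (on this read-out higher numbers stand for weaker inhibition and lower numbers for stronger inhibition), compound 3 gives 1900 nM, the higher of the two true numbers here, and so the weaker inhibition of that pair. Compound 1 gives only a limit of the assay.

Compound 4 `COc1cc(C(=O)c2ccc3c(ccn3CC(=O)O)c2)cc(OC)c1OC` differs from compound 3 by carboxy in place of ethyl on a saturated chain carbon bound to an aromatic nitrogen. In words, this is carboxy in place of ethyl on a saturated chain carbon bound to an aromatic nitrogen. The same difference, cut one bond further out, reads propyl to carboxymethyl.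

Going by the values given here, one measured step bears on this change, since it falls on the same chain: methyl in place of hydrogen on a saturated chain carbon, two bonds along the chain from an aromatic nitrogen. That step is large, a 53-fold higher number from compound 2 to compound 3 (1.72 log units; beyond the scatter), and it shows that this assay can respond strongly to a small change at this chain. Among the compounds with values here, no measured compound carries a carboxy group, so the expectation rests on that single step and remains uncertain. A further move toward weaker inhibition, smaller than that measured step, is expected, estimated as a 3.2-fold higher number from compound 3 to compound 4 (0.50 log units; beyond the scatter). For compound 4 the estimated value is 6000 nM, with an expected range from 1000 nM to 30000 nM.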

Compound 4, half-maximal inhibitory concentration: 520 nM
The estimate for compound 4 lay 12-fold (1.06 log units) above the measured number; measured number outside the range, below it.
By their numbers in this assay, from the lowest: compound 2; then compound 4; then compound 3. At a limit, above all of these: compound 1.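

Carboxy in place of ethyl gives a 3.7-fold lower number from compound 3 to compound 4 (0.56 log units; beyond the scatter), so in this assay a change at the far end of this chain can also move the number down, whereas the only earlier step here, a 53-fold higher number from compound 2 to compound 3 (1.72 log units; beyond the scatter), went up. Compound 4 also carries more heavy atoms in the entering carboxy than compound 3 carries in the leaving ethyl, so among these compounds a larger group at this position does not always mean weaker inhibition. The gain is only partial, however, as carboxy in place of methyl gives a 14-fold higher number from compound 2 to compound 4 (1.16 log units; beyond the scatter), which leaves compound 2 the stronger inhibitor of that pair.

The compounds shown leave open whether an amine or a methyl ester in the same place, or a longer chain ending in a carboxylic acid, would behave more like compound 4 or more like compound 3. Nothing measured here tells why the carboxy group shifts the number in this way.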